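The compounds below may be only part of what the source reports. "The series", "measured", "known", "first", "only" and "open" are said of these compounds alone.

Compound 1: `Cc1cc(CC(=O)O)ccc1-c1noc(-c2ccc(C3CCCCC3)cc2)n1` — in a functional assay on CHO cells for agonist activity at sphingosine 1-phosphate receptor 5 (Homo sapiens), read by GTPgammaS binding (on this read-out higher numbers stand for an effect only at larger amounts of compound and lower numbers for an effect already at smaller amounts), compound 1 gives 4000 nM.
Compound 2: `COc1ccc(-c2nc(-c3ccc(CCC(=O)O)cc3C)no2)cc1C(F)(F)F` — in this assay compound 2 gives 2600 nM.
Compound 3: `Cc1cc(CCC(=O)O)ccc1-c1noc(-c2ccc(OC(C)C)c(F)c2)n1` — in this assay compound 3 gives 530 nM.

Of the three measured compounds, compound 3 has the lowest number, so it acts already at the smallest amount of compound. Its nearest neighbour is compound 2, whose number is higher by more than the usual scatter, and compound 1 lies further off still. Compound 4, `Cc1cc(CCC(=O)O)ccc1-c1noc(-c2ccc(OC(C)C)c(Br)c2)n1`, has not yet been measured. It differs from compound 3 in one place: bromo in place of fluoro on an aromatic carbon. For the measured compounds named here, no pair of measured compounds differs by a single such change, so there is no measured step to lean on. A swap of one halogen for another at the same position is a small change in a molecule of this size, and the expectation is a step in this assay that stays within the scatter, with no clear direction. Compound 4 is therefore estimated at about 450 nM, most likely between 150 nM and 1400 nM, which means an expected step of a 1.2-fold lower number from compound 3 to compound 4 (0.07 log units; within the scatter).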

Compound 4, half-maximal effective concentration: 43 nM
Estimate against measurement, compound 4: 10-fold (1.02 log units) above; the whole stated range lies above it.
By their numbers in this assay, from the lowest: compound 4; then compound 3; then compounds 2 and 1 (each within the scatter of the next).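

In this assay, putting bromo in place of fluoro, ortho to the isopropoxy group, gives a 12-fold lower number from compound 3 to compound 4 (1.09 log units; beyond the scatter). This is the first change at a single place among the compounds shown, and it reveals that this aromatic carbon is far from indifferent to which halogen it carries, even though one heavy atom replaces another and the count of hydrogen-bond donors and acceptors stays the same. No measurement on hand explains why the two halogens differ so much.

With only fluoro and bromo compared at this carbon, the compounds leave open where chloro, iodo or a nitrile would fall. They also leave open whether a step of this size would survive if an ethoxy or cyclobutoxy group replaced the isopropoxy group.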